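The source may hold more compounds than are shown below. What is called first, only, known or untested is meant among the compounds shown, and "the series" means these compounds.

Compound 2 `O=C(Nc1ccc(Oc2ccnc3[nH]ccc23)c(F)c1)c1cn(-c2ccc(Br)cc2)c2ccccc2c1=O` carries a bromo group where compound 1 `O=C(Nc1ccc(Oc2ccnc3[nH]ccc23)c(F)c1)c1cn(-c2ccc(Cl)cc2)c2ccccc2c1=O` carries chloro. In a functional assay on A549 cells (Homo sapiens) for inhibition, read by MTT assay, with a stated time of 72 h (a higher number here means a weaker inhibitor, a lower number a stronger inhibitor), compound 1 gives 320 nM, and compound 2 gives 950 nM, the higher of the two numbers, with a 3.0-fold higher number from compound 1 to compound 2 (0.47 log units; beyond the scatter). Compound 3 `O=C(Nc1ccc(Oc2ccnc3[nH]ccc23)c(F)c1)c1cn(-c2ccc(Br)cc2F)c2ccccc2c1=O` differs from compound 2 by fluoro in place of hydrogen on an aromatic carbon, turning 4-bromophenyl into 4-bromo-2-fluorophenyl. For the measured compounds named here, no measured step exchanges hydrogen for fluoro; the only known step, a halogen swap, does not bear on it. The expected change in this assay is therefore none beyond the scatter, a 1.1-fold lower number from compound 2 to compound 3 (0.02 log units; within the scatter). Compound 3 is estimated at 900 nM, within 300 nM to 2700 nM.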

Compound 3, half-maximal inhibitory concentration: 1150 nM
The estimate for compound 3 lay 1.3-fold (0.11 log units) below the measured number; measured number inside the range.
By their numbers in this assay, from the lowest: compound 1; then compounds 2 and 3 (each within the scatter of the next).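

Fluoro in place of hydrogen on the 4-bromophenyl ring gives a 1.2-fold higher number from compound 2 to compound 3 (0.08 log units; within the scatter) in this assay so at this place on the ring the added atom brings no change that can be told from scatter. Replacing 4-chlorophenyl with 4-bromo-2-fluorophenyl gives a 3.6-fold higher number from compound 1 to compound 3 (0.56 log units; beyond the scatter) and so the added fluoro does not close the gap beyond the scatter that separates the bromo compounds from compound 1. Nothing available here explains these numbers. As far as these compounds go, whether fluoro behaves the same on the 4-chlorophenyl ring remains open, as does the effect of a methoxy group or an amine at this place.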